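Adding a methyl to the amide nitrogen of compound 2

This account rests on a few compounds, and the source may have more. Where it says the series, first, only, none or still open, it means among the compounds named here.

Compound 1 `O=C(N[C@H]1CN(S(=O)(=O)c2ccccc2)C[C@@H]1C(=O)N[C@H]1CCCNC1)c1nnc(-c2ccc(F)cc2)s1` gives 1 in a physicochemical assay for lipophilicity, measured as octanol-water partition, at pH 7.4; on this read-out lower numbers stand for lower lipophilicity and higher numbers for higher lipophilicity
Compound 2 `O=C(N[C@H]1CN(S(=O)(=O)c2ccccc2)C[C@@H]1C(=O)N[C@H]1CCCNC1)c1cc(-c2ccccc2Cl)on1` gives 1.9
Compound 3 `O=C(N[C@H]1CN(S(=O)(=O)c2ccccc2)C[C@@H]1C(=O)NC[C@@H]1CCCN1)c1cc(-c2ccccc2Cl)on1` gives 1.5

Compound 2 stands highest of the three in this assay at 1.9 on this scale. Compound 4 `CN(C(=O)c1cc(-c2ccccc2Cl)on1)[C@H]1CN(S(=O)(=O)c2ccccc2)C[C@@H]1C(=O)N[C@H]1CCCNC1` differs from it by one change methyl in place of hydrogen on an amide-type nitrogen with methyl in place of hydrogen on an amide-type nitrogen. Neither measured step touches that nitrogen. The modest a number 0.90 log units higher from compound 1 to compound 2 (beyond the scatter) came with a change on a carbonyl carbon. The modest a number 0.40 log units lower from compound 2 to compound 3 (beyond the scatter) came with (pyrrolidin-2-yl)methyl in place of piperidin-3-yl on another amide-type nitrogen. Among the compounds with values here, no measured pair shows a methyl change, so only a small upward step is expected, smaller than either and possibly within the scatter. The estimated step is a number 0.20 log units higher from compound 2 to compound 4 (within the scatter) and no larger one is expected. Compound 4 is expected at 2.1 with an estimated range from 1.7 to 2.5 in this read-out.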

Compound 4, distribution coefficient: 1.6
The estimate for compound 4 lay 0.50 log units above the measured number; measured number below the stated range.
By their numbers in this assay, from the lowest: compound 1; then compounds 3, 4 and 2 (each within the scatter of the next, the first and the last beyond it).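

In this assay, methyl in place of hydrogen on this amide-type nitrogen gives a number 0.30 log units lower from compound 2 to compound 4 (within the scatter). Within the data shown here, this is the first reading at this nitrogen, and it separates compound 4 from compound 2 by no more than the usual scatter. Nothing measured here accounts for the result. Still open, on these data alone, is whether an ethyl group or a longer chain on this nitrogen would give a step beyond the scatter. Also open, as far as these compounds go, is whether methyl would give a similar step with the (pyrrolidin-2-yl)methyl of compound 3 or the carbonyl substituent of compound 1.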